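This account rests on a few compounds, and the source may have more. Where it says the series, first, only, none or still open, it means among the compounds named here.

Within the data shown here, compound 1 `COc1cccc(COc2ccc3cc(C(=O)/C=C/c4cc(OC)ccc4OC)c(=O)oc3c2)c1` is one of two compounds measured in a functional assay on MOLT-4 cells (Homo sapiens) for cytotoxicity, read by MTT assay, with a stated time of 72 h; a higher number here means a weaker inhibitor, a lower number a stronger inhibitor. In this assay compound 1 gives 13800 nM, the higher of the two numbers. Compound 2 `COc1cc(/C=C/C(=O)c2cc3ccc(O)cc3oc2=O)cc(OC)c1OC` gives 3800 nM in this assay, a lower number that lies beyond the usual scatter of repeated measurements; the two structures differ in more than one place, so their values can only be taken as they stand. Compound 3 `COc1cccc(COc2ccc3cc(C(=O)/C=C/c4ccc(C)cc4)c(=O)oc3c2)c1` has not yet been measured in this assay. It differs from compound 1 in one place: 4-methylphenyl in place of 2,5-dimethoxyphenyl on a double-bonded chain carbon bound to a double-bonded chain carbon. Among the measured compounds shown here, no single-place step between measured compounds is known, so nothing here shows how such a swap shifts the number. The step of a 1.2-fold lower number from compound 1 to compound 3 (0.06 log units; within the scatter) is therefore expected to be small, in either direction or none beyond the scatter. Compound 3 is expected to give about 12000 nM in this assay, within 4000 nM to 36000 nM.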

Compound 3, half-maximal inhibitory concentration: > 50000 nM
Compound 3 was reported as a limit; the forecaster's own chance of this, stated with the estimate: 10%; at least 4.1-fold (0.61 log units) between middle value and limit.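

In this assay the reading for compound 3 is a limit and not a number: the limit of > 50000 nM in this assay, at which 1 of the 3 values shown sits. Even so, this gives the first single-place step among the compounds shown: 4-methylphenyl in place of 2,5-dimethoxyphenyl, on a double-bonded chain carbon bound to a double-bonded chain carbon, gives an at least 3.6-fold higher number from compound 1 to compound 3 (0.55 log units; beyond the scatter). The group at this place is therefore not interchangeable, and this swap moves the number towards a weaker inhibitor while the rest of the structure stays the same.

This one step changes the two methoxy groups and the methyl group together, so it cannot show which of them accounts for the shift. On these data alone, how a phenyl ring carrying an amine or a carboxylic acid at this place would read also remains open.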